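Amino in place of fluoro: expectations for compound 3

A few compounds are considered here, and "the series" means these few. Any claim that something is new, unique, unknown or untested is made for them only; others in the source may bear on it.

In a functional assay on MCF7 cells (Homo sapiens) for cytotoxicity, read by MTT assay, with a stated time of 96 h (on this read-out higher numbers stand for weaker inhibition and lower numbers for stronger inhibition), compound 1 (`COc1cc(C(=O)c2cn(-c3cccc(C)c3)cc2-c2ccccc2[N+](=O)[O-])cc(OC)c1OC`) gives 220 nM and compound 2 (`COc1cc(C(=O)c2cn(-c3ccc(F)cc3)cc2-c2ccccc2[N+](=O)[O-])cc(OC)c1OC`) gives 38 nM as the lower of the two numbers. Compound 3 (`COc1cc(C(=O)c2cn(-c3ccc(N)cc3)cc2-c2ccccc2[N+](=O)[O-])cc(OC)c1OC`) has amino in place of fluoro on an aromatic carbon, para to a large group (amino in place of fluoro on an aromatic carbon). Among the compounds with values here, the only measured step (a 5.8-fold lower number from compound 1 to compound 2 (0.76 log units; beyond the scatter)) is modest and introduced the 4-fluorophenyl group now being changed. It involves a different swap and sets no direction here, so no shift beyond the scatter is expected in this assay for this change. The expected step (a 1.1-fold higher number from compound 2 to compound 3 (0.02 log units; within the scatter)) is correspondingly small. Compound 3 is estimated at 40 nM with an expected range from 10 nM to 170 nM in this assay.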

Compound 3, half-maximal inhibitory concentration: 53 nM
Estimate against measurement, compound 3: 1.3-fold (0.12 log units) below; measured number inside the range.
By their numbers in this assay, from the lowest: compounds 2 and 3 (each within the scatter of the next); then compound 1.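

In this assay the change from 4-fluorophenyl to 4-aminophenyl gives a 1.4-fold higher number from compound 2 to compound 3 (0.14 log units; within the scatter), so at this position amino and fluoro cannot be told apart. The step with a 4.2-fold lower number from compound 1 to compound 3 (0.62 log units; beyond the scatter) places the 4-aminophenyl group with the 4-fluorophenyl group, clear of the 3-methylphenyl group. No supporting data bear on why these numbers fall as they do.

Open, as far as these compounds go, is whether a carboxylic acid at this place would stay at the same level. Also open, from the compounds shown here alone, is whether a dimethylamino group or an acetamide would keep the number of the free amino group.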